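Pyrimidin-2-yl for 4-fluorophenyl on the ring amine nitrogen

The source may report more compounds than this note shows. Statements on the series, on what has been measured and on what is new or still open speak of the compounds shown alone.

Measured so far in a functional assay on the whole organism (strain CD-1) with Mus musculus as the target, in the maximal electroshock model, with a stated time of 0.5 h; on this read-out higher numbers stand for an effect only at larger amounts of compound and lower numbers for an effect already at smaller amounts:
compound 1, `CC1(c2ccccc2)CC(=O)N(CC(=O)N2CCN(c3ccc(Cl)cc3)CC2)C1=O`: "not active" (no number reported)
compound 2, `Cc1cccc(N2CCN(C(=O)CN3C(=O)CC(C)(c4ccccc4)C3=O)CC2)c1`: 100 mg/kg
compound 3, `CC1(c2ccccc2)CC(=O)N(CC(=O)N2CCN(c3ccc(F)cc3)CC2)C1=O`: 100 mg/kg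

Compound 3 stands level with compound 2 at the digits given; the step of no change at the digits printed from compound 2 to compound 3 (within the scatter) lies within the scatter. Compound 1 returned no number in this assay.

Compound 4, `CC1(c2ccccc2)CC(=O)N(CC(=O)N2CCN(c3ncccn3)CC2)C1=O`, differs from compound 3 by pyrimidin-2-yl in place of 4-fluorophenyl on an amine nitrogen in a ring. For the measured compounds named here, the only step that bears on this is the one from compound 2 to compound 3, also a change of the group on the ring amine nitrogen, and it stayed within the scatter. Compound 1 shows that such a change can also remove the effect, but gives no number to scale by. For compound 4 no step beyond the scatter is expected, no change at the digits printed from compound 3 to compound 4 (within the scatter), and the estimate in this assay is 100 mg/kg, from 50 mg/kg to 200 mg/kg.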

Compound 4, minimum effective dose: "not active" (no number reported)
The entry for compound 4 holds no number, and the estimate cannot be compared.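

In this assay compound 4 gives "not active" (no number reported), so no step from compound 3 to compound 4 can be read, and nothing shown accounts for this result. The compounds shown leave open how far compound 4 stands from compound 3 on this read-out.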